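This account rests on a few compounds, and the source may have more. Where it says the series, first, only, none or still open, it means among the compounds named here.

In an ADME assay on HepG2 cells (Homo sapiens) for cytotoxicity (a lower number here means that less compound is tolerated, a higher number that more compound is tolerated), compound 1 `CSc1cncc(N2C(=O)CN(c3cccc(C(F)(F)F)c3)CC2C(=O)NC2CCCC2)c1` gives 26000 nM and compound 2 `CC(=O)c1cccc(N2C(=O)CN(c3cccc(C(F)(F)F)c3)CC2C(=O)NC2CCCC2)c1` gives 40000 nM as its half-maximal cytotoxic concentration. These two numbers are all there is so far, and compound 2 stands level with compound 1 within the scatter. The next compound, compound 3 `O=C(NC1CCCC1)C1CN(c2cccc(C(F)(F)F)c2)CC(=O)N1c1cccc(OC(F)(F)F)c1`, keeps the core of compound 2 and carries one change (trifluoromethoxy in place of acetyl on an aromatic carbon), trifluoromethoxy in place of acetyl on an aromatic carbon, meta to a large group. Going by the values given here, only one measured step bears on this, and only indirectly. That step (a 1.5-fold higher number from compound 1 to compound 2 (0.19 log units; within the scatter)) replaced the whole group on the amide-type nitrogen in a ring and stayed within the scatter. Among the compounds with values here, no measured compound carries trifluoromethoxy. In this assay no step beyond the scatter is therefore expected. The estimated step (a 1.3-fold lower number from compound 2 to compound 3 (0.10 log units; within the scatter)) is accordingly small. For compound 3 the expected value is 32000 nM with an estimated range from 14000 nM to 65000 nM in this read-out.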

Compound 3, half-maximal cytotoxic concentration: 8000 nM
Compound 3: middle estimate off by 4.0-fold (0.60 log units), on the high side; the measured number lies below the stated range.
By their numbers in this assay, from the lowest: compound 3; then compounds 1 and 2 (each within the scatter of the next).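

In this assay, the exchange of acetyl for trifluoromethoxy on an aromatic carbon, meta to a large group, gives a 5.0-fold lower number from compound 2 to compound 3 (0.70 log units; beyond the scatter), so a change in this one substituent moves the number beyond the scatter. The earlier step, a 1.5-fold higher number from compound 1 to compound 2 (0.19 log units; within the scatter), replaced the whole group on the amide-type nitrogen in a ring and stayed within the scatter, whereas the corresponding replacement that brings in the 3-(trifluoromethoxy)phenyl group gives a 3.3-fold lower number from compound 1 to compound 3 (0.51 log units; beyond the scatter). Nothing measured here explains why trifluoromethoxy and acetyl differ in this way. The compounds shown leave open whether the lower number is particular to trifluoromethoxy or would also appear with a methoxy, a chlorine or a nitrile at this place. They also do not tell whether an amine or a carboxylic acid there would shift the number in the opposite direction.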